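A few compounds are considered here, and "the series" means these few. Any claim that something is new, unique, unknown or untested is made for them only; others in the source may bear on it.

Working notes on the amide series in a functional assay on A549 cells (Homo sapiens) for inhibition, read by sulforhodamine B assay, with a stated time of 72 h; a higher number here means a weaker inhibitor, a lower number a stronger inhibitor. Compound 1 `CC1CN(C(=O)c2c(N)sc(-c3ccc(Cl)cc3)c2-c2ccc(Cl)cc2)CCN1` gives 4930 nM, compound 2 `CCCCNC(=O)c1c(N)sc(-c2ccc(Cl)cc2)c1-c1ccc(Cl)cc1` gives 8170 nM, and compound 3 `CC(C)CNC(=O)c1c(N)sc(-c2ccc(Cl)cc2)c1-c1ccc(Cl)cc1` gives 21000 nM. Compound 3 has the highest number of the three and is the weakest inhibitor here, with its steps to both others beyond the scatter.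

Compound 4 `Nc1sc(-c2ccc(Cl)cc2)c(-c2ccc(Cl)cc2)c1C(=O)NCc1ccccc1` comes next: phenyl in place of isopropyl on a saturated chain carbon bound to an amide-type nitrogen. Read one bond further out, the change is isobutylamino to benzylamino.

The closest measured change is a 2.6-fold higher number from compound 2 to compound 3 (0.41 log units; beyond the scatter), where only the chain end differs. The other step out of compound 3's neighbours is a 4.3-fold higher number from compound 1 to compound 3 (0.63 log units; beyond the scatter), while a 1.7-fold higher number from compound 1 to compound 2 (0.22 log units; within the scatter) shows no separation. Among the measured compounds shown here, no measured compound carries a phenyl, so this rests on thin evidence. With compound 3 at the top of the range, a modest move to a lower number is expected in this assay. The estimated step is a 2.1-fold lower number from compound 3 to compound 4 (0.32 log units; beyond the scatter). For compound 4 the estimate is 10000 nM, with an expected range of 4500 nM to 24000 nM.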

Compound 4, half-maximal inhibitory concentration: 16300 nM
Beside the measured number, compound 4's estimate is 1.6-fold (0.21 log units) below it; the range from low to high includes it.
By their numbers in this assay, from the lowest: compounds 1, 2, 4 and 3 (each within the scatter of the next, the first and the last beyond it).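

In this assay the first aromatic ring at this place, on a saturated chain carbon bound to an amide-type nitrogen, does not separate phenyl from isopropyl (a 1.3-fold lower number from compound 3 to compound 4 (0.11 log units; within the scatter)) or from propyl (a 2.0-fold higher number from compound 2 to compound 4 (0.30 log units; within the scatter)). On the carbonyl carbon, benzylamino joins isobutylamino in reading apart from 3-methylpiperazin-1-yl (a 3.3-fold higher number from compound 1 to compound 4 (0.52 log units; beyond the scatter)), whereas butylamino does not. Nothing available here bears on the reason for any of these steps.

From the compounds shown here alone, whether a chlorobenzyl group or the longer phenethyl chain would separate from benzyl at this place remains open. Also open, going by these compounds, is whether morpholine or unsubstituted piperazine on the carbonyl carbon would read with compound 1 or with the open-chain amides.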